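Working notes on compounds 1 to 4

The source may report more compounds than this note shows. Statements on the series, on what has been measured and on what is new or still open speak of the compounds shown alone.

Measured so far:
Compound 1, `COc1cc(-c2nn(-c3cccc(NC(=O)Nc4ccc(Cl)c(Cl)c4)c3)cc2-c2ccncc2)ccc1Cl`. In a functional assay on SN12C cells (Homo sapiens) for inhibition, read by sulforhodamine B assay, with a stated time of 48 h (a lower number here means a stronger inhibitor of growth, a higher number a weaker inhibitor of growth), compound 1 gives only a limit, > 50000 nM.
Compound 2, `O=C(Nc1cccc(-n2cc(-c3ccncc3)c(-c3ccc(Cl)c(O)c3)n2)c1)Nc1ccc(Cl)c(Cl)c1`. In this assay compound 2 gives only a limit, > 32500 nM.
Compound 3, `COc1cc(-c2nn(-c3cccc(NC(=O)c4ccccc4)c3)cc2-c2ccncc2)ccc1Cl`. In this assay compound 3 gives only a limit, > 100000 nM.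

Compound 2 stands at a limit and not at a number, namely (the limit of > 32500 nM in this assay, at which 1 of the 3 values shown sits). The other two values are limits as well, one at the limit of > 50000 nM in this assay, at which 1 of the 3 values shown sits, and one at the limit of > 100000 nM in this assay, at which 1 of the 3 values shown sits, so none of the three compounds can be ordered against another. The two measured steps, a step that the two limits leave unreadable from compound 1 to compound 2 and a step that the two limits leave unreadable from compound 1 to compound 3, are both unreadable between limits and give no direction.

Compound 4, `O=C(Nc1cccc(-n2cc(-c3ccncc3)c(-c3ccc(Cl)c(O)c3)n2)c1)Nc1ccc(Cl)c(C(F)(F)F)c1`, differs from compound 2 by trifluoromethyl in place of chloro on an aromatic carbon. Among the measured compounds shown here, no measured step touches this position, and the steps that exist are unreadable, so nothing argues for a gain beyond the scatter. Compound 4 is therefore expected to sit at or near the limit as well, with the estimated step that the limit leaves unreadable from compound 2 to compound 4 counted as none beyond the scatter. The estimate for compound 4 is 50000 nM, expected to fall between 10000 nM and 100000 nM, most likely reported again as a limit.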

Compound 4, concentration for total growth inhibition: 17100 nM
Compound 4: the middle estimate sits 2.9-fold (0.47 log units) above what was measured, and the stated range covers the measured number.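

In this assay, among the compounds shown here, compound 4 gives 17100 nM, a number and not a limit, which is the first readable value and the first information on this position of the urea's outer ring. Compound 2, the partner in this comparison, gives only a limit: the limit of > 32500 nM in this assay, at which 1 of the 4 values shown sits. Going from 3,4-dichlorophenyl to 4-chloro-3-(trifluoromethyl)phenyl is therefore read as an at least 1.9-fold lower number from compound 2 to compound 4 (0.27 log units; that floor lies within the scatter), so the true step may be larger, but this floor alone does not establish a gain.

As far as these compounds go, the steps among compounds 1, 2 and 3 cannot be read, so the size of this step and whether it carries over to the methoxy analogue, compound 1, remain open. Also open, from the compounds shown here alone, is how a nitrile or a bromo group in place of trifluoromethyl at this position would read.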